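Cytotoxicity notes: furan to pyridine on the biaryl arm

The source may hold more compounds than are shown below. What is called first, only, known or untested is meant among the compounds shown, and "the series" means these compounds.

Three measured compounds share one core. Compound 1 `CC1(Cc2ccccc2)CC(S(=O)(=O)c2cccc(C(F)(F)F)c2)=C(c2ccc(/C(N)=N\O)cc2)O1` gives 33400 nM in an ADME assay on HepG2 cells (Homo sapiens) for cytotoxicity, read by MTT assay, with a stated time of 72 h; a higher number here means that more compound is tolerated, a lower number that less compound is tolerated. Compound 2 `CC1(Cc2ccccc2)CC(S(=O)(=O)c2cccc(F)c2)=C(c2ccc(/C(N)=N\O)cc2)O1` gives 59600 nM in this assay. Within the data shown here, the only measured single-point step, a 1.8-fold higher number from compound 1 to compound 2 (0.25 log units; within the scatter), is within the scatter. Compound 3 `CC1(c2ccc(-c3ccco3)cc2)CC(S(=O)(=O)c2ccc(F)cc2)=C(c2ccc(/C(N)=N\O)cc2)O1` gives 7010 nM in this assay and stands lowest of the three numbers, beyond the scatter below both compound 1 and compound 2, so less of compound 3 is tolerated than of either.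

Compound 4 `CC1(c2ccc(-c3ccncc3)cc2)CC(S(=O)(=O)c2ccc(F)cc2)=C(c2ccc(/C(N)=N\O)cc2)O1` differs from compound 3 in one place: pyridin-4-yl in place of furan-2-yl on an aromatic carbon. Among the measured compounds shown here, no measured step covers this exchange; the one measured step, a 1.8-fold higher number from compound 1 to compound 2 (0.25 log units; within the scatter), concerns another position and another pair of groups, so nothing at hand points in either direction. For compound 4 the expectation is therefore no step beyond the scatter, a 1.1-fold higher number from compound 3 to compound 4 (0.06 log units; within the scatter), with the range widened for want of a precedent. Compound 4 is estimated at 8000 nM in this assay, with a range from 3000 nM to 25000 nM.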

Compound 4, half-maximal cytotoxic concentration: 30300 nM
Beside the measured number, compound 4's estimate is 3.8-fold (0.58 log units) below it, outside the stated range (above it).
By their numbers in this assay, from the lowest: compound 3; then compounds 4, 1 and 2 (each within the scatter of the next).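

In this assay, among these compounds, the change from 4-(furan-2-yl)phenyl to 4-(pyridin-4-yl)phenyl gives a 4.3-fold higher number from compound 3 to compound 4 (0.64 log units; beyond the scatter), the first single-place step to lie beyond the scatter. This position, on an aromatic carbon para to a large group, therefore affects how much compound is tolerated, and in this pair the low number of compound 3 does not persist once furan-2-yl is replaced by pyridin-4-yl. No measurement at hand accounts for the step.

The pair cannot separate the departure of furan-2-yl from the arrival of pyridin-4-yl; an unsubstituted phenyl, pyridin-3-yl or thiophen-2-yl group at the same place would help to tell these apart. From the compounds shown here alone, whether the exchange gives a similar step on the other compounds, with their different groups elsewhere on the shared core, also remains open.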